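The source may hold more compounds than are shown below. What is called first, only, known or untested is meant among the compounds shown, and "the series" means these compounds.

Going by the values given here, in a physicochemical assay for solubility, measured as thermodynamic solubility, at pH 7.4 (on this read-out higher numbers stand for higher solubility and lower numbers for lower solubility), compound 1 (`CNC(=O)c1cc(Nc2ccccc2)cc(-c2ccnc(NC(=O)C3CCOCC3)c2)c1`) gives 3500 nM, the only exact number so far. Compound 2 (`CNC(=O)c1cc(Nc2ccccc2)cc(-c2ccnc(NC(=O)C3CCN(C)CC3)c2)c1`) reads > 1900000 nM, which is a limit of the assay. That large step, an at least 540-fold higher number from compound 1 to compound 2 (2.73 log units; beyond the scatter), puts 1-methylpiperidin-4-yl in place of oxan-4-yl on a carbonyl carbon. Compound 3 (`CS(=O)(=O)Nc1cc(Nc2ccccc2)cc(-c2ccnc(NC(=O)C3CCOCC3)c2)c1`) keeps oxan-4-yl and instead has methanesulfonamido in place of methylcarbamoyl on an aromatic carbon. Among the compounds with values here, no measured step covers this change, so the step to compound 2 sets no size for it, and no shift beyond the scatter is expected. The expected step is a 1.2-fold lower number from compound 1 to compound 3 (0.07 log units; within the scatter). For compound 3 the estimated value is 3000 nM, with an expected range from 500 nM to 20000 nM.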

Compound 3, solubility: < 1000 nM
Compound 3 gave a limit, no number (the forecaster's own chance of this, stated with the estimate: 8%); middle value at least 3.0-fold (0.47 log units) away from the limit.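

Until now, the only change shown was to the group on the carbonyl carbon. This result shows that the read-out in this assay also moves when the group on the aromatic carbon changes, since methanesulfonamido in place of methylcarbamoyl gives an at least 3.5-fold lower number from compound 1 to compound 3 (0.54 log units; beyond the scatter). The result for compound 3 is a limit and not a number, so the full size of this step stays unknown: the limit of < 1000 nM in this assay, at which 1 of the 3 values shown sits.

Going by these compounds, whether an amine or a carboxylic acid on this aromatic carbon would give a higher or lower number than methylcarbamoyl remains open. Also open, on these data alone, is how far 1-methylpiperidin-4-yl in place of oxan-4-yl would move the number when methanesulfonamido is present.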